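Swapping the aryl amine group on a shared urea core

A few compounds are considered here, and "the series" means these few. Any claim that something is new, unique, unknown or untested is made for them only; others in the source may bear on it.

Compound 1, `COc1cc(NC(=O)Nc2cc(Nc3cccc(C(C)(C)C)c3)ncn2)cc(OC)c1`, is one of three ureas built on the same core and tested in a functional assay on HCC827 cells (Homo sapiens) for inhibition, read by MTT assay, with a stated time of 48 h, tested at 10 uM (on this read-out lower numbers stand for less inhibition and higher numbers for more inhibition at the one concentration tested (going by the name of the read-out)), where compound 1 gives 48.7%. That places it second highest of the three: compound 2, `CC(C)(C)c1cccc(Nc2cc(NC(=O)Nc3c(Cl)cccc3Cl)ncn2)c1`, gives 37.3%, and compound 3, `COc1ccc(Nc2cc(NC(=O)Nc3c(Cl)cccc3Cl)ncn2)cc1C`, gives 63.1%. Within the data shown here, only one single-point step is available: a number 11.4 percentage points lower from compound 1 to compound 2 (beyond the scatter), which swaps the aryl on the urea end, not the aryl on the ring nitrogen.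

Compound 4, `COc1cc(NC(=O)Nc2cc(Nc3ccc(C)c(C)c3)ncn2)cc(OC)c1`, is not yet measured. It differs from compound 1 in one place: 3,4-dimethylphenyl in place of 3-(tert-butyl)phenyl on a nitrogen on an aromatic ring. Among the measured compounds shown here, no measured step changes exactly this group while holding everything else fixed, so the expectation rests on indirect hints. Compounds 2 and 3, which share the 2,6-dichlorophenyl urea end but carry different groups elsewhere, sit well apart in this assay, showing that the other end of the molecule can matter by more than the scatter. With no direct comparison, a small change is the safest guess, and compound 4 is expected to show a number 3.3 percentage points higher from compound 1 to compound 4 (within the scatter), a step within the scatter. Compound 4 is therefore estimated at 52%, with a range from 35% to 70%.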

Compound 4, a percentage reported as inhibition, at one concentration (the size of the read-out at that concentration, not a potency): 45.7%
Estimate against measurement, compound 4: 6.3 percentage points above; measured number inside the range.
By their numbers in this assay, from the lowest: compounds 2, 4 and 1 (each within the scatter of the next, the first and the last beyond it); then compound 3.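

On the nitrogen on an aromatic ring, putting 3,4-dimethylphenyl in place of 3-(tert-butyl)phenyl gives a number 3 percentage points lower from compound 1 to compound 4 (within the scatter) in this assay, and this is the only step shown at this position. With the 3,5-dimethoxyphenyl group held fixed at the urea end, going from 10 heavy atoms to 8 in this all-carbon aryl group leaves two numbers that cannot be told apart, so this particular change shows no effect that stands clear of the usual variation between repeats. No separate measurement is available that could say why the two groups read alike.

From the compounds shown here alone, it remains open whether the same holds with the 2,6-dichlorophenyl group at the urea end, where the group on the ring nitrogen is different in each compound and compound 2 gives 37.3% while compound 3 gives 63.1%. Also open, going by these compounds, is whether a phenyl ring carrying an amine or a carboxylic acid at this position, instead of the carbon-only groups seen so far, would shift the number by more than the usual variation.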